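A few compounds are considered here, and "the series" means these few. Any claim that something is new, unique, unknown or untested is made for them only; others in the source may bear on it.

In a functional assay on K562 cells (Homo sapiens), read by MTT assay, with a stated time of 72 h (a lower number here means a stronger inhibitor, a higher number a weaker inhibitor), compound 1 `COc1ncnc2c1c(-c1ccoc1)cn2[C@@H]1O[C@H](CO)[C@@H](O)[C@H]1O` gives 2820 nM. Compound 2 `CN(C)c1ncnc2c1c(-c1ccoc1)cn2[C@@H]1O[C@H](CO)[C@@H](O)[C@H]1O` gives 14900 nM in this assay. Compound 3 `CN(C)c1ncnc2c1c(-c1cc3ccccc3o1)cn2[C@@H]1O[C@H](CO)[C@@H](O)[C@H]1O` reaches only a limit of this assay, > 20000 nM; that is the limit of > 20000 nM in this assay, at which 1 of the 3 values shown sits, not a number.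

Two steps are counted among these. a 5.3-fold lower number from compound 2 to compound 1 (0.72 log units; beyond the scatter) goes with methoxy in place of dimethylamino on an aromatic carbon. an at least 1.3-fold higher number from compound 2 to compound 3 (0.12 log units; that floor lies within the scatter) goes with 1-benzofuran-2-yl in place of furan-3-yl on an aromatic carbon, and this is also how the core of compound 3 differs from the core of compound 2.

Compound 4 `COc1ncnc2c1c(-c1cc3ccccc3o1)cn2[C@@H]1O[C@H](CO)[C@@H](O)[C@H]1O` is not yet measured in this assay. It differs from compound 3 by methoxy in place of dimethylamino on an aromatic carbon, the same change as from compound 2 to compound 1 at the same place. Because compound 3 shows only > 20000 nM, the step from compound 3 to compound 4 can be expected at roughly an at least 2.5-fold lower number from compound 3 to compound 4 (0.39 log units; beyond the scatter), resting on the earlier step alone. Compound 4 is estimated at 8000 nM, expected between 3000 nM and 25000 nM.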

Compound 4, half-maximal inhibitory concentration: 13100 nM
Compound 4: middle estimate off by 1.6-fold (0.21 log units), on the low side; the range from low to high includes it.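

Compound 3 stands in this assay at > 20000 nM, which is a limit of the assay and not a number. Carried to the second core, methoxy in place of dimethylamino gives an at least 1.5-fold lower number from compound 3 to compound 4 (0.18 log units; that floor lies within the scatter), so the step is not shown to lie beyond the scatter there, and whether it keeps its size across the cores is not shown: the same change on two cores in this assay, a 5.3-fold lower number (0.72 log units; beyond the scatter) from compound 2 to compound 1 and an at least 1.5-fold lower number (0.18 log units; that floor lies within the scatter) from compound 3 to compound 4; the limit leaves it open whether they differ Read on the methoxy pair, 1-benzofuran-2-yl in place of furan-3-yl gives a 4.6-fold higher number from compound 1 to compound 4 (0.67 log units; beyond the scatter), and whether this matches the step on the dimethylamino pair remains equally unsettled: the same change on two cores in this assay, an at least 1.3-fold higher number (0.12 log units; that floor lies within the scatter) from compound 2 to compound 3 and a 4.6-fold higher number (0.67 log units; beyond the scatter) from compound 1 to compound 4; the limit leaves it open whether they differ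

The compounds shown leave open how an ethoxy or a plain amino group at that aromatic carbon would compare with methoxy and dimethylamino. They also leave open whether a thiophene ring in place of the furan-3-yl would follow the same course.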